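Acetoxy to hydroxy in a series at its limit

The source may hold more compounds than are shown below. What is called first, only, known or untested is meant among the compounds shown, and "the series" means these compounds.

In an ADME assay on DU-145 cells (Homo sapiens) for cytotoxicity, read by MTT assay, with a stated time of 72 h (a higher number here means a weaker inhibitor, a lower number a stronger inhibitor), compound 1 `COc1ccc(C2=C(c3cc(OC)c(OC)c(OC)c3)C(=O)CC2C)cc1C(=O)O` gives > 100 ug/mL as a limit and not a number. Compound 3 `COc1ccc(C2=C(c3cc(OC)c(OC)c(OC)c3)C(=O)CC2O[SiH2]C(C)(C)C)cc1` likewise gives > 100 ug/mL as a limit in this assay and not a number. Compound 2 `COc1ccc(C2=C(c3cc(OC)c(OC)c(OC)c3)C(=O)C(OC(C)=O)C2)cc1` also gives > 100 ug/mL as a limit, so it has no exact standing in this assay and cannot be ranked against the other two. The same picture, (the limit of > 100 ug/mL in this assay, at which 3 of the 3 values shown sit), holds for the whole measured set.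

Compound 4 `COc1ccc(C2=C(c3cc(OC)c(OC)c(OC)c3)C(=O)C(O)C2)cc1` departs from compound 2 in one place: hydrogen in place of acetyl on an oxygen on a saturated carbon gives hydrogen in place of acetyl on an oxygen on a saturated carbon, the change from acetoxy to hydroxy. Going by the values given here, no measured pair in the set shows what such a change does. Any movement in this assay is expected to be toward stronger inhibition, though no shift beyond the scatter remains possible. The estimated step of an at least 1.4-fold lower number from compound 2 to compound 4 (0.15 log units; that floor lies within the scatter) is expected to be modest. For compound 4 the estimated value is 70 ug/mL with an expected range from 15 ug/mL to 200 ug/mL in this measurement.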

Compound 4, half-maximal inhibitory concentration: > 100 ug/mL
Compound 4: no number, only a limit; the forecaster's own chance of this, stated with the estimate: 55%; at least 1.4-fold (0.15 log units) between middle value and limit.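

In this assay compound 4 gives > 100 ug/mL, a limit and not a number. Compound 2 also stands at a limit, so the change from acetoxy to hydroxy between compound 2 and compound 4 cannot be read. The compounds shown leave open whether this change moves inhibition at all, and how strongly any of them inhibits, with one reading shared by the whole set: the limit of > 100 ug/mL in this assay, at which 4 of the 4 values shown sit.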